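Methoxy to ethoxy on a shared benzofuran-bearing core

The compounds below may be only part of what the source reports. "The series", "measured", "known", "first", "only" and "open" are said of these compounds alone.

Of the compounds shown here, three have been measured in a functional assay on aorta (strain Wistar) for inhibition, with Thoracic aorta (Rattus norvegicus) as the target; a higher number here means a weaker inhibitor, a lower number a stronger inhibitor. Compound 1 `CCOc1nc(-c2cc3ccccc3o2)cc(-c2ccccc2)c1C#N` gives 310000 nM. Compound 2 `CCOc1nc(-c2cc3ccccc3o2)cc(-c2ccc3ccccc3c2)c1C#N` gives 423000 nM. Compound 3 `COc1nc(-c2cc3ccccc3o2)cc(-c2ccc(Br)cc2)c1C#N` gives 298000 nM. Compound 3 carries the smallest of the three numbers, but its distance to compound 1 and to compound 2 lies within the scatter, so no ranking among the three can be read from these values. Among the measured compounds shown here, the only step between two compounds that differ in a single place is a 1.4-fold higher number from compound 1 to compound 2 (0.13 log units; within the scatter), and it also stays within the scatter.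

The unmeasured compound 4 `CCOc1nc(-c2cc3ccccc3o2)cc(-c2ccc(Br)cc2)c1C#N` differs from compound 3 by methyl in place of hydrogen on a saturated chain carbon bound to an oxygen on an aromatic ring; cut one bond further out, the change reads methoxy to ethoxy. For the measured compounds named here, no measured pair isolates this change: compound 1 and compound 2 carry the ethoxy group while compound 3 carries the methoxy, yet each of those pairs also differs in the aryl group on the aromatic carbon. Going by the values given here, with the one measured step, a 1.4-fold higher number from compound 1 to compound 2 (0.13 log units; within the scatter), showing no movement beyond the scatter and all three values lying in a narrow band, no shift beyond the scatter is expected here. The expected step amounts to a 1.0-fold higher number from compound 3 to compound 4 (0.00 log units; within the scatter). In this assay compound 4 is therefore expected to give about 300000 nM, within a range from 150000 nM to 600000 nM.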

Compound 4, half-maximal inhibitory concentration: 227000 nM
Beside the measured number, compound 4's estimate is 1.3-fold (0.12 log units) above it, within the range that was stated.
By their numbers in this assay, from the lowest: compounds 4, 3, 1 and 2 (each within the scatter of the next).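

In this assay, among the compounds shown here, the step gives a 1.3-fold lower number from compound 3 to compound 4 (0.12 log units; within the scatter), the first reading that isolates methoxy to ethoxy on the shared core, and with the 4-bromophenyl group held constant the added methyl on a saturated chain carbon bound to an oxygen on an aromatic ring leaves no readable mark. With the ethoxy group held constant, the aryl group can now be read in two further ways: bromo in place of hydrogen on an aromatic carbon gives a 1.4-fold lower number from compound 1 to compound 4 (0.14 log units; within the scatter) for this change, and 4-bromophenyl in place of naphthalen-2-yl on an aromatic carbon gives a 1.9-fold lower number from compound 2 to compound 4 (0.27 log units; within the scatter) for this change, so neither aryl change separates these compounds. Nothing available here bears on the reason for these results.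

The compounds shown leave open whether a longer chain, such as butoxy, or a chain ending in an amine or a carboxylic acid, would carry the number beyond the scatter at this position. They also leave open whether replacing the bromo group with an amine or a hydroxyl group on the aromatic carbon would do so.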